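Sulfamoyl for methyl on the triazole aryl of spirooxindole series

The source may report more compounds than this note shows. Statements on the series, on what has been measured and on what is new or still open speak of the compounds shown alone.

Compound 1 `Cc1cccc(-n2nncc2CN2C(=O)C3(C(C#N)=C(N)Oc4c3c3nc5ccccc5nc3c3ccccc43)c3ccccc32)c1` sits at a limit in a functional assay on MCF7 cells (Homo sapiens) for antiproliferative activity, read by MTT assay, with a stated time of 48 h; a higher number here means a weaker inhibitor, a lower number a stronger inhibitor: compound 1 gives > 50000 nM, which is a limit of the assay and not a number. For the measured compounds named here, its one neighbour, compound 2 `N#CC1=C(N)Oc2c(c3nc4ccccc4nc3c3ccccc23)C12C(=O)N(Cc1cnnn1-c1ccc(Cl)cc1)c1ccccc12`, carries 4-chlorophenyl in place of 3-methylphenyl on an aromatic nitrogen. In this assay compound 2 gives > 50000 nM, again a limit. The step that the two limits leave unreadable from compound 1 to compound 2 is therefore not readable in size, and both values sit at the limit of > 50000 nM in this assay, at which 2 of the 2 values shown sit.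

Compound 3 `N#CC1=C(N)Oc2c(c3nc4ccccc4nc3c3ccccc23)C12C(=O)N(Cc1cnnn1-c1cccc(S(N)(=O)=O)c1)c1ccccc12` is not yet measured. It differs from compound 1 by sulfamoyl in place of methyl on an aromatic carbon. Going by the values given here, no measured step bears on this change, since the only step known is the unreadable one from compound 1 to compound 2. With two compounds at the limit, the expectation for compound 3 in this assay is that it stays near the same limit, an expected step that the limit leaves unreadable from compound 1 to compound 3. Compound 3 is estimated at 60000 nM, between 20000 nM and 200000 nM.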

Compound 3, half-maximal inhibitory concentration: 42500 nM
The estimate for compound 3 lay 1.4-fold (0.15 log units) above the measured number; measured number inside the range.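

In this assay, for the compounds shown here, compound 3 gives 42500 nM, the only number so far, which makes 3-sulfamoylphenyl the first group on the aromatic nitrogen to give a readable value. Sulfamoyl in place of methyl gives an at least 1.1-fold lower number from compound 1 to compound 3 (0.07 log units; that floor lies within the scatter), and 3-sulfamoylphenyl in place of 4-chlorophenyl gives an at least 1.1-fold lower number from compound 2 to compound 3 (0.07 log units; that floor lies within the scatter). Both steps are floors only, so the data show no firm gain from either change, and their true sizes cannot be read: the limit of > 50000 nM in this assay, at which 2 of the 3 values shown sit.

On these data alone, it remains open whether a number in this range is specific to sulfamoyl or would also appear with an amine, a carboxylic acid or methylsulfonyl on the same ring carbon. Also open, as far as these compounds go, is whether any group at this place can bring the value far below that of compound 3.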